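Solubility notes: phenyl to methoxycarbonyl-piperidinyl on the shared core

The source may hold more compounds than are shown below. What is called first, only, known or untested is meant among the compounds shown, and "the series" means these compounds.

Measured so far, in a physicochemical assay for solubility, in phosphate buffer, at pH 7.4; a lower number here means a less soluble compound, a higher number a more soluble compound:
compound 1 `OCC1CCN(c2nccnc2OC2CN(c3ncc4ccccc4n3)C2)CC1` — compound 1 gives 174000 nM
compound 2 `OCCC1CCN(c2nccnc2OC2CN(c3ccc4ccccc4n3)C2)CC1` — compound 2 gives 84000 nM
compound 3 `c1ccc(-c2nccnc2OC2CN(c3ccc4ccccc4n3)C2)cc1` — compound 3 gives < 1000 nM

For compound 3 the value is a limit of the assay, not a number; compound 3 sits at the limit of < 1000 nM in this assay, at which 1 of the 3 values shown sits. Compound 1 and compound 2 both give numbers, with compound 1 the higher of the two. Within the data shown here, the one step measured is an at least 84-fold lower number from compound 2 to compound 3 (1.92 log units; beyond the scatter), so compound 3 stands at the bottom of the three.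

Compound 4 `COC(=O)N1CCC(c2nccnc2OC2CN(c3ccc4ccccc4n3)C2)CC1` is not yet measured. It differs from compound 3 by 1-(methoxycarbonyl)piperidin-4-yl in place of phenyl on an aromatic carbon.

The step that bears on this change is the measured one from compound 2 to compound 3, where a substituted piperidin-1-yl gave way to phenyl and the number fell beyond the scatter. Compound 4 runs the other way, phenyl giving way to a piperidin-4-yl, though the entering group carries a methoxycarbonyl and no hydroxyl. A rise beyond the scatter is therefore expected in this assay, smaller than the measured step. Compound 4 is estimated at 10000 nM, in the range 2000 nM to 50000 nM. The expected step is an at least 10-fold higher number from compound 3 to compound 4 (1.00 log units; beyond the scatter).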

Compound 4, solubility: 138000 nM
Compound 4: middle estimate off by 14-fold (1.14 log units), on the low side, and the stated range ends below it.
By their numbers in this assay, from the lowest: compounds 2, 4 and 1 (each within the scatter of the next, the first and the last beyond it). At a limit, below all of these: compound 3.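

At this place on the shared core, next to the ring nitrogen, this assay gives an at least 130-fold higher number from compound 3 to compound 4 (2.13 log units; beyond the scatter), so a high number is not tied to the 4-(2-hydroxyethyl)piperidin-1-yl group alone. The comparison between the two saturated groups gives a 1.6-fold higher number from compound 2 to compound 4 (0.22 log units; within the scatter), which lies within the scatter: 1-(methoxycarbonyl)piperidin-4-yl, with 0 hydrogen-bond donors and attached through a ring carbon, cannot be told apart here from the hydroxyethyl group attached through the piperidine nitrogen. The full size of the change from phenyl stays unread, since the entry for compound 3 is a limit and not a number: the limit of < 1000 nM in this assay, at which 1 of the 4 values shown sits.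

Still open is whether the methoxycarbonyl contributes to the high number, since the compounds shown do not separate it from the non-aromatic ring that carries it; a free piperidine amine or an acetyl group on the same nitrogen would bear on this. Also open, going by these compounds, is whether a small non-aromatic ring, such as cyclopropyl or a morpholine, would sit with the piperidine-bearing compounds or nearer to phenyl at this place.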